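The source may hold more compounds than are shown below. What is called first, only, known or untested is meant among the compounds shown, and "the series" means these compounds.

Compound 3 `COc1ccc(/C=C2\NC(=O)N(CCCN3CCN(c4ccccc4OC)CC3)C2=O)cc1OC1CCCC1` belongs to a small set of hydantoin-based arylpiperazines examined in an assay on CHO cells for displacement of a labelled ligand from 5-hydroxytryptamine receptor 7 (Homo sapiens), read by scintillation counting, with a stated time of 60 min; on this read-out higher numbers stand for weaker inhibition and lower numbers for stronger inhibition. Compound 1 `COc1ccc(/C=C2\NC(=O)N(CCCN3CCN(c4ccccc4OC)CC3)C2=O)cc1OC` shares the core with compound 3 and differs only in the alkoxy group; in this assay compound 1 gives 42 nM. The change of cyclopentyl in place of methyl on an oxygen on an aromatic ring produces a 7.0-fold lower number from compound 1 to compound 3 (0.85 log units; beyond the scatter), so that compound 3 gives 6 nM. Compound 2 `COc1ccc(/C=C2\NC(=O)N(CCCCN3CCN(c4cccc(Cl)c4Cl)CC3)C2=O)cc1OC` differs from the others in both the linker and the aryl group on the piperazine, and in this assay compound 2 gives 0.8 nM. Among the three numbers, compound 3 stands second, with compound 1 higher and compound 2 lower.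

Compound 4 `COc1ccc(/C=C2\NC(=O)N(CCCN3CCN(c4ncccn4)CC3)C2=O)cc1OC1CCCC1` is the next step from compound 3: pyrimidin-2-yl in place of 2-methoxyphenyl on an amine nitrogen in a ring. Within the data shown here, no measured step in this set bears directly on this change, since the only single-point step, from compound 1 to compound 3, concerns the alkoxy group and not the aryl on the piperazine, and compound 2 differs from compound 3 in two places at once. The step from compound 3 to compound 4 is therefore expected to be modest, most likely toward a higher number, estimated as a 3.3-fold higher number from compound 3 to compound 4 (0.52 log units; beyond the scatter). Compound 4 is expected to give 20 nM in this assay, within a range of 4 nM to 100 nM.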

Compound 4, inhibition constant: > 1000 nM
Compound 4 gave a limit, no number; the forecaster's own chance of this, stated with the estimate: 2%; middle value at least 50-fold (1.69 log units) from the limit.
By their numbers in this assay, from the lowest: compound 2; then compound 3; then compound 1. At a limit, above all of these: compound 4.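

In this assay, the group on the amine nitrogen in a ring carries far more weight than the alkoxy group did: pyrimidin-2-yl in place of 2-methoxyphenyl gives an at least 160-fold higher number from compound 3 to compound 4 (2.22 log units; beyond the scatter), whereas cyclopentyl in place of methyl on an oxygen gave a 7.0-fold lower number from compound 1 to compound 3 (0.85 log units; beyond the scatter). The value of compound 4 is a limit of the assay and not a number, and the step is read against that limit: the limit of > 1000 nM in this assay, at which 1 of the 4 values shown sits. The result also shows that the cyclopentyl group shared by compound 3 and compound 4 does not keep the number low once 2-methoxyphenyl is replaced by pyrimidin-2-yl.

The compounds shown leave open whether the change in the number follows the two ring nitrogens of pyrimidin-2-yl or the loss of the methoxy group, a question that a plain phenyl or a pyridin-2-yl on the same nitrogen would help to separate. From the compounds shown here alone, it also remains open whether this replacement would have a similar effect with the linker of compound 2.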